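The compounds below may be only part of what the source reports. "The series", "measured", "known", "first", "only" and "open" are said of these compounds alone.

Notes on the series. Compound 3 `COC(=O)[C@@]1(C)CC[C@@H]2C3=C1CC[C@@H](C)[C@]3(C)C[C@@H]1c3cc(Br)ccc3N[C@H]21` gives 25000 nM in a functional assay on HeLa cells (Homo sapiens) for inhibition, read by sulforhodamine B assay, with a stated time of 48 h (a lower number here means a stronger inhibitor of growth, a higher number a weaker inhibitor of growth), the highest of the three numbers gathered so far. Compound 2 `COC(=O)[C@@]1(C)CC[C@@H]2C3=C1CC[C@@H](C)[C@]3(C)C[C@@H]1c3cc(C)ccc3N[C@H]21` gives 18000 nM in this assay and lies within the scatter of compound 3; compound 1 `COC(=O)[C@@]1(C)CCC=C2[C@@H]1CC[C@@H](C)[C@]2(C)Cc1c(C)[nH]c2ccc(Br)cc12` gives 11000 nM in this assay and lies beyond the scatter below compound 3. Compound 4 `COC(=O)[C@@]1(C)CC[C@@H]2C3=C1CC[C@@H](C)[C@]3(C)C[C@@H]1c3cc(OC)ccc3N[C@H]21` differs from compound 3 by methoxy in place of bromo on an aromatic carbon. Within the data shown here, the only measured step that bears on a swap of this kind, a 1.4-fold higher number from compound 2 to compound 3 (0.14 log units; within the scatter), stayed within the scatter. Among the measured compounds shown here, no measured compound carries methoxy, so the expectation rests on that single step alone. In this assay compound 4 is expected to show a 1.3-fold lower number from compound 3 to compound 4 (0.10 log units; within the scatter), no change beyond the scatter. Compound 4 is therefore estimated at 20000 nM in this assay, with a range from 8000 nM to 50000 nM.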

Compound 4, concentration for 50% growth inhibition: 20000 nM
Compound 4: middle estimate and measured number agree at the digits printed; the measured number falls inside the stated range.
By their numbers in this assay, from the lowest: compounds 1, 2, 4 and 3 (each within the scatter of the next, the first and the last beyond it).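

In this assay, methoxy on this aromatic carbon gives a 1.3-fold lower number from compound 3 to compound 4 (0.10 log units; within the scatter) and a 1.1-fold higher number from compound 2 to compound 4 (0.05 log units; within the scatter), so methyl, bromo and methoxy cannot be told apart here. The swap from bromo to methoxy adds a hydrogen-bond acceptor and one more heavy atom, yet moves the number by no more than the scatter. Nothing available explains why these steps stay so small. Still open, from the compounds shown here alone, is whether an amine or a carboxylic acid on this carbon would move the number beyond the scatter. Going by these compounds, whether a longer chain such as butoxy would do so also remains open.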